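This account rests on a few compounds, and the source may have more. Where it says the series, first, only, none or still open, it means among the compounds named here.

Within the data shown here, compound 2 `CC(C)(C)c1ccc(C(=O)N2CCC3(CC2)C(=O)N(CC(=O)NCCCCCNS(C)(=O)=O)CN3c2ccccc2)cc1` holds the lower of the two numbers so far in an assay on HEK293 cells for displacement of a labelled ligand from NPC1-like intracellular cholesterol transporter 1 (Homo sapiens) (on this read-out lower numbers stand for stronger inhibition and higher numbers for weaker inhibition), where compound 2 gives 5500 nM. Among the measured compounds shown here, its only measured neighbour is compound 1 `CC(C)(C)c1ccc(C(=O)N2CCC3(CC2)C(=O)N(CC(=O)N2CCN(S(C)(=O)=O)CC2)CN3c2ccccc2)cc1`, which in this assay gives 19000 nM; the change a 3.5-fold lower number from compound 1 to compound 2 (0.54 log units; beyond the scatter) came from putting an open-chain sulfonamide-bearing amine in place of the sulfonyl-piperazine on the carbonyl carbon. Compound 3 `CC1(C)CC(OC(=O)CN2CN(c3ccccc3)C3(CCN(C(=O)c4ccc(C(C)(C)C)cc4)CC3)C2=O)CC(C)(C)N1` is built from compound 2 by the change ((2,2,6,6-tetramethylpiperidin-4-yl)oxy in place of (5-(methanesulfonamido)pentyl)amino on a carbonyl carbon). For the measured compounds named here, only that single measured step bears on this alteration, and it touched the same carbonyl carbon, so its size gives the scale to expect; the step to compound 3 exchanges the amide link for an ester and removes the sulfonamide, which no measured pair covers. Compound 3 is therefore estimated to sit near compound 2, with an expected step of a 1.4-fold lower number from compound 2 to compound 3 (0.14 log units; within the scatter) in this assay, giving an estimate of 4000 nM within the range 1500 nM to 12000 nM.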

Compound 3, half-maximal inhibitory concentration: 1300 nM
The estimate for compound 3 lay 3.1-fold (0.49 log units) above the measured number; measured number below the stated range.
By their numbers in this assay, from the lowest: compound 3; then compound 2; then compound 1.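

On the carbonyl carbon in this assay, the (2,2,6,6-tetramethylpiperidin-4-yl)oxy group gives a 4.2-fold lower number from compound 2 to compound 3 (0.63 log units; beyond the scatter) and a 15-fold lower number from compound 1 to compound 3 (1.16 log units; beyond the scatter), so the open chain of compound 2 is not needed for the lowest number seen so far at this position. Neither is a sulfur-bearing group, since compound 3 has none; a ring alone does not set the order, though, since compound 1 also carries a ring at this place and has the highest number of the three. Nothing measured here explains these steps.

As far as these compounds go, the step to compound 3 changes the link and the group at once, so their shares remain open. A (2,2,6,6-tetramethylpiperidin-4-yl)amino amide would isolate the link, and a piperidin-4-yloxy group without the methyl groups would test those methyls.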